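A few compounds are considered here, and "the series" means these few. Any claim that something is new, unique, unknown or untested is made for them only; others in the source may bear on it.

Of the compounds shown here, three have been measured in an assay on membranes from striatum (strain Sprague-Dawley) for displacement of a labelled ligand from sodium-dependent dopamine transporter (Rattus norvegicus), read by scintillation counting, with a stated time of 120 min; on this read-out higher numbers stand for weaker inhibition and lower numbers for stronger inhibition. Compound 1 `[O-][S+](CCNC1CCN(Cc2ccc(F)cc2)CC1)C(c1ccc(F)cc1)c1ccc(F)cc1` gives 50.6 nM, compound 2 `OC(Cc1ccccc1)CN1CCC(NCCSC(c2ccc(F)cc2)c2ccc(F)cc2)CC1` gives 31.4 nM, and compound 3 `[O-][S+](CCNC1CCN(CC(O)Cc2ccccc2)CC1)C(c1ccc(F)cc1)c1ccc(F)cc1` gives 91.8 nM. Compound 2 has the lowest of these three numbers: its gap to compound 1 is within the usual scatter, while its gap to compound 3 lies beyond it. Within the data shown here, the only measured pair that differs in one place is compound 1 and compound 3, where a 1.8-fold higher number from compound 1 to compound 3 (0.26 log units; within the scatter) was found after exchanging the group on a saturated chain carbon bound to an amine nitrogen in a ring.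

Compound 4 `Fc1ccc(C(SCCNC2CCN(Cc3cc4ccccc4o3)CC2)c2ccc(F)cc2)cc1` has not yet been measured. It differs from compound 2 at that same place: 1-benzofuran-2-yl in place of 1-hydroxy-2-phenylethyl on a saturated chain carbon bound to an amine nitrogen in a ring. Among the measured compounds shown here, the step from compound 1 to compound 3 is the only measured precedent bearing on this change, since it altered the same position, and it stayed within the scatter. For the measured compounds named here, no measured compound carries the entering group, so its own effect is unknown. On this basis no step beyond the scatter is expected in this assay. Compound 4 is therefore estimated at 35 nM, with a range from 12 nM to 100 nM. The expected step is a 1.1-fold higher number from compound 2 to compound 4 (0.05 log units; within the scatter).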

Compound 4, inhibition constant: 120 nM
The estimate for compound 4 lay 3.4-fold (0.54 log units) below the measured number, outside the stated range (above it).
By their numbers in this assay, from the lowest: compounds 2, 1, 3 and 4 (each within the scatter of the next, the first and the last beyond it).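

In this assay, among these compounds, the new step, a 3.8-fold higher number from compound 2 to compound 4 (0.58 log units; beyond the scatter), lies beyond the scatter, so this position on a saturated chain carbon bound to an amine nitrogen in a ring can respond to a change of group, which the only earlier step here, a 1.8-fold higher number from compound 1 to compound 3 (0.26 log units; within the scatter), within the scatter, did not show. The response also appears without any change in the count of heavy atoms: 1-hydroxy-2-phenylethyl and 1-benzofuran-2-yl hold the same carbons and oxygen, yet the entering group has a five-membered aromatic ring and no hydrogen-bond donor, while the leaving group has one donor. No measurement here explains why the number rose, so neither of these differences can be named as the cause.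

The ring change and the loss of the hydroxyl arrive together in this step, and a plain 2-phenylethyl group in the same place, with the hydroxyl gone but no benzofuran present, would be needed to pull them apart. From the compounds shown here alone, it also remains open whether 1-benzofuran-2-yl would give a similar step on the core of compound 1, where the sulfur carries an oxygen.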